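The source may report more compounds than this note shows. Statements on the series, on what has been measured and on what is new or still open speak of the compounds shown alone.

Measured so far in a functional assay on PC-3 cells (Homo sapiens) for inhibition, read by sulforhodamine B assay, with a stated time of 48 h; on this read-out higher numbers stand for weaker inhibition of growth and lower numbers for stronger inhibition of growth:

Compound 1, `C=C(C)[C@@H]1CC=C(Cn2cc(COc3ccc(C4NC(=O)NC(C)=C4C(=O)OCC)cc3)nn2)CC1`, gives 92200 nM.
Compound 2, `C=C(C)[C@@H]1CC=C(Cn2cc(COc3ccc(C4NC(=O)NC(C)=C4C(=O)OCC)cc3OC)nn2)CC1`, gives 54400 nM.
Compound 3, `C=C(C)[C@@H]1CC=C(Cn2cc(COc3cccc(C4NC(=O)NC(C)=C4C(C)=O)c3)nn2)CC1`, gives 49800 nM.

Compounds 1 and 2 share a core and differ in one place, (methoxy in place of hydrogen on an aromatic carbon). That change made a 1.7-fold lower number from compound 1 to compound 2 (0.23 log units; within the scatter). Compound 3 carries a different core; the difference between the two cores is not broken down here. Compound 4, `C=C(C)[C@@H]1CC=C(Cn2cc(COc3cc(C4NC(=O)NC(C)=C4C(C)=O)ccc3OC)nn2)CC1`, is not yet measured. It differs from compound 3 by methoxy in place of hydrogen on an aromatic carbon. This is the same kind of change as that from compound 1 to compound 2, though the surroundings of the place differ: there the position was ortho to a large group and meta to a large group, here it is ortho to a large group and para to a large group. Because a 1.7-fold lower number from compound 1 to compound 2 (0.23 log units; within the scatter) stayed within the scatter, a similarly small step is expected, a 1.4-fold lower number from compound 3 to compound 4 (0.15 log units; within the scatter), giving an estimate for compound 4 of 35000 nM with a range from 15000 nM to 90000 nM.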

Compound 4, concentration for total growth inhibition: > 100000 nM
Compound 4: a limit, no number; the forecaster's own chance of this, stated with the estimate: 10%; middle value at least 2.8-fold (0.45 log units) from the limit.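

In this assay compound 4 gives > 100000 nM, which is a limit of the assay and not a number. Methoxy in place of hydrogen on an aromatic carbon therefore did not carry over unchanged from one core to the other, as an at least 2.0-fold higher number from compound 3 to compound 4 (0.30 log units; that floor lies within the scatter) stands against a 1.7-fold lower number from compound 1 to compound 2 (0.23 log units; within the scatter), and the two steps differ: the same change on two cores in this assay, a 1.7-fold lower number (0.23 log units; within the scatter) from compound 1 to compound 2 and an at least 2.0-fold higher number (0.30 log units; that floor lies within the scatter) from compound 3 to compound 4, at least 3.4-fold (0.53 log units) apart, beyond the scatter of two such steps This rests on one pair per core, does not show which difference between the cores matters, and gives only a floor for the second step, whose true size remains unknown: the limit of > 100000 nM in this assay, at which 1 of the 4 values shown sits.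

Going by these compounds, whether an ethoxy, a hydroxyl or an amine on that same aromatic carbon would follow either step stays open. So does how methoxy would behave on further cores.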